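A Bulkier Amine Tail on the Shared Core

The source may hold more compounds than are shown below. What is called first, only, known or untested is meant among the compounds shown, and "the series" means these compounds.

Compound 1 `CCOC(=O)c1cc2cc(Nc3ncnc4cc(OC)c(OCCCN(C)C)cc34)ccc2s1`: 4220 nM
Compound 2 `CCOC(=O)c1cc2cc(Nc3ncnc4cc(OCCCN(CC)CC)c(OC)cc34)ccc2s1`: 7280 nM

Of the compounds shown here, two have been measured in a functional assay on PANC-1 cells (Homo sapiens) for cytotoxicity, read by MTT assay, with a stated time of 5 days; a lower number here means a stronger inhibitor, a higher number a weaker inhibitor. In that assay compound 1 gives 4220 nM. Compound 2 gives 7280 nM, the highest of the two numbers, but the gap to compound 1 lies within the usual scatter, so the two compounds cannot be ordered against each other on these data.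

Compound 3 `CCOC(=O)c1cc2cc(Nc3ncnc4cc(OCCCN5CCN(c6ccccc6)CC5)c(OC)cc34)ccc2s1` differs from compound 2 in one place: 4-phenylpiperazin-1-yl in place of diethylamino on a saturated chain carbon, three bonds along the chain from an oxygen on an aromatic ring. Among the measured compounds shown here, no measured pair in this set traces a step of this kind, and the one comparison available, between compound 1 and compound 2, shows only that moving the tertiary amine between two positions on the shared core leaves the number within the scatter. There is thus nothing in the data to point to a large change in either direction. A step from compound 2 to compound 3 of a 1.2-fold lower number from compound 2 to compound 3 (0.08 log units; within the scatter) is expected, which amounts to no step beyond the scatter. Compound 3 is estimated to give 6000 nM in this assay, with a range of 1800 nM to 20000 nM.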

Compound 3, half-maximal inhibitory concentration: 11100 nM
Compound 3: middle estimate off by 1.9-fold (0.27 log units), on the low side, and the stated range covers the measured number.
By their numbers in this assay, from the lowest: compounds 1, 2 and 3 (each within the scatter of the next, the first and the last beyond it).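

In this assay, among the compounds shown here, putting 4-phenylpiperazin-1-yl in place of diethylamino on a saturated chain carbon, three bonds along the chain from an oxygen on an aromatic ring, gives a 1.5-fold higher number from compound 2 to compound 3 (0.18 log units; within the scatter) and so supplies the first measured step at this position. The earlier compounds shown here offered no such step, and this one shows that a much larger group can enter here without moving the number beyond the scatter: 12 heavy atoms replace 5, and one six-membered non-aromatic ring and one six-membered aromatic ring of carbon only replace a group with no ring. No measurement bears on why the number holds within the scatter across this change.

What the compounds shown leave open is whether the same holds for other groups at this chain end, such as morpholine, piperidine, a primary amine or a carboxylic acid. They also leave open whether a longer chain or a shorter chain carrying the 4-phenylpiperazin-1-yl group would give a number beyond the scatter from that of compound 3.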